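From a Propyl Chain to a Carbamoylethyl Chain

The source may hold more compounds than are shown below. What is called first, only, known or untested is meant among the compounds shown, and "the series" means these compounds.

The set holds three measured compounds and one awaiting measurement, all built on the same shared core. Compound 1 `N#CCCCc1c[nH]c2ccc(C(=O)O)cc12` carries a nitrile-terminated chain and a carboxylic acid and is reported in an assay on isolated protein (urine) for inhibition of Myeloperoxidase (Homo sapiens), with a stated time of 5 min (a higher number here means a weaker inhibitor, a lower number a stronger inhibitor), as "not active" (no number reported). Compound 3 `NC(=O)CCc1c[nH]c2c(F)cccc12` carries a 2-carbamoylethyl chain, with its fluorine at a different position, and gives 271 nM in this assay. Compound 2 `CCCc1c[nH]c2ccc(F)cc12` carries a propyl chain; in this assay compound 2 gives only a limit, > 100 nM, so no single number exists for it and it cannot be ranked against the other two (the limit of > 100 nM in this assay, at which 1 of the 3 values shown sits). Compound 4 `NC(=O)CCc1c[nH]c2ccc(F)cc12` is not yet measured and differs from compound 2 in one place: carbamoyl in place of methyl on a saturated chain carbon, two bonds along the chain from an aromatic carbon.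

Among the compounds with values here, no step between measured compounds that differ in a single place is available. Compound 3 shows that a 2-carbamoylethyl chain on this core can yield a numbered value of 271 nM in this assay. The step from the propyl chain to the carbamoylethyl chain is expected to be a step that the limit leaves unreadable from compound 2 to compound 4, modest and close to the scatter. Compound 4 is therefore estimated at 300 nM, with a range from 90 nM to 1500 nM. Since compound 2 itself returned only a limit, a fair chance remains that compound 4 also returns a limit rather than a number.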

Compound 4, half-maximal inhibitory concentration: 132 nM
For compound 4 the middle estimate is 2.3-fold (0.36 log units) above the measured one; measured number inside the range.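

The change from the propyl chain of compound 2 to the 2-carbamoylethyl chain of compound 4 yields no readable step, since compound 2 stands in this assay only as a limit: the limit of > 100 nM in this assay, at which 1 of the 4 values shown sits.

The compounds shown leave open how large the effect of this single change on inhibition really is.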